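Exchanging the acid-bearing outer ring once more

A few compounds are considered here, and "the series" means these few. Any claim that something is new, unique, unknown or untested is made for them only; others in the source may bear on it.

Within the data shown here, compound 2 `Cc1ccc(C(=O)O)cc1-c1cccc(COc2ccc3c(c2)CN(C2CCCC2)C3=O)c1` has the lowest number of the two compounds measured so far in an assay on HEK293 cells for positive allosteric modulation of metabotropic glutamate receptor 2 (Rattus norvegicus), read by thallium flux (a lower number here means that less compound is needed, a higher number that more compound is needed for the effect), where compound 2 gives 110 nM. Among the measured compounds shown here, its only neighbour is compound 1 `COc1ccc(-c2cccc(COc3ccc4c(c3)CN(C3CCCC3)C4=O)c2)cc1C(=O)O`, which in this assay gives 170 nM; the step of a 1.5-fold lower number from compound 1 to compound 2 (0.19 log units; within the scatter) lies within the scatter, so the two compounds cannot be told apart on these numbers.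

Compound 3 `O=C(O)c1ccc(-c2cccc(COc3ccc4c(c3)CN(C3CCCC3)C4=O)c2)c(Cl)c1` has not yet been measured. It differs from compound 2 in one place: 4-carboxy-2-chlorophenyl in place of 5-carboxy-2-methylphenyl on an aromatic carbon. A chlorine thus stands where a methyl group stood, and the carboxylic acid sits at a different position of the same ring.

For the measured compounds named here, only one measured step bears on this change: a 1.5-fold lower number from compound 1 to compound 2 (0.19 log units; within the scatter), which also exchanged the group on this aromatic carbon and stayed within the scatter. With the two measured values this close, no step beyond the scatter is expected for compound 3 in either direction. Compound 3 is therefore expected to give 130 nM in this assay, with a range from 50 nM to 350 nM, which corresponds to an expected step of a 1.2-fold higher number from compound 2 to compound 3 (0.07 log units; within the scatter).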

Compound 3, half-maximal effective concentration: 110 nM
Compound 3: the middle estimate sits 1.2-fold (0.07 log units) above what was measured; measured number inside the range.
By their numbers in this assay, from the lowest: compounds 2, 3 and 1 (each within the scatter of the next).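

In this assay, putting 4-carboxy-2-chlorophenyl in place of 5-carboxy-2-methylphenyl gives no change at the digits printed from compound 2 to compound 3 (within the scatter), and putting it in place of 3-carboxy-4-methoxyphenyl gives a 1.5-fold lower number from compound 1 to compound 3 (0.19 log units; within the scatter). This aromatic carbon has now carried three differently substituted outer rings, with a methoxy group, a methyl group or a chlorine and with the carboxylic acid at differing places on the ring, yet the three compounds cannot be told apart on these numbers. The step from compound 2 to compound 3 exchanges methyl for chlorine and moves the acid at once, so the share of each change cannot be read from it, and no measurement at hand accounts for the three compounds reading alike.

Going by these compounds, what a 4-carboxy-2-methylphenyl group would give, which would separate those two changes, remains open. Also open, on these data alone, is whether the carboxylic acid itself matters, since all three compounds carry one and the effect of an amide or a tetrazole in its place is unknown.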